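Benzyl for methoxyphenyl on the aromatic nitrogen

A few compounds are considered here, and "the series" means these few. Any claim that something is new, unique, unknown or untested is made for them only; others in the source may bear on it.

Measured so far:
compound 1 `c1ccc(CNc2c(-c3ccccn3)nc3ccccn23)cc1` — > 50000 nM
compound 2 `COc1ccc(Nc2c(-c3ccccn3)nc3ccc(C)cn23)cc1` — 10700 nM
compound 3 `COc1cccc(Nc2c(-c3ccccn3)nc3ccc(C)cn23)c1` — 13200 nM

In an ADME assay on THP-1 cells (Homo sapiens) for cytotoxicity (a higher number here means that more compound is tolerated, a lower number that less compound is tolerated), compound 1 gives only a limit, > 50000 nM, not a number. Of the two numbers, compound 3 has the higher, with compound 2 within the scatter of it: a 1.2-fold higher number from compound 2 to compound 3 (0.09 log units; within the scatter). Compound 4 `Cc1ccc2nc(-c3ccccn3)c(NCc3ccccc3)n2c1` differs from compound 3 in that (benzyl in place of 3-methoxyphenyl on a nitrogen on an aromatic ring). Among the compounds with values here, no measured step covers this change; the one measured step concerns the methoxy position only and stayed within the scatter. Compound 1 carries the same benzyl group on a core without the methyl and reaches the limit (the limit of > 50000 nM in this assay, at which 1 of the 3 values shown sits). Compound 4 is therefore expected to show a higher number in this assay, a 3.0-fold higher number from compound 3 to compound 4 (0.48 log units; beyond the scatter); the estimate for compound 4 is 40000 nM, within 15000 nM to 100000 nM.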

Compound 4, half-maximal cytotoxic concentration: > 50000 nM
Compound 4: no number, only a limit; the forecaster's own chance of this, stated with the estimate: 50%; at least 1.2-fold (0.09 log units) between middle value and limit.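

In this assay compound 4 gives only a limit, > 50000 nM, not a number. On the nitrogen on an aromatic ring, benzyl separates clearly from both methoxyphenyl groups, with an at least 3.7-fold higher number from compound 3 to compound 4 (0.57 log units; beyond the scatter) and an at least 4.6-fold higher number from compound 2 to compound 4 (0.66 log units; beyond the scatter), whereas moving the methoxy group alone stayed within the scatter. The step for the added methyl, compound 1 against compound 4, cannot be read, as both values are limits: the limit of > 50000 nM in this assay, at which 2 of the 4 values shown sit.

Open, from the compounds shown here alone, is how far the two benzyl compounds lie past that limit. Also open, going by these compounds, is whether a longer chain in place of benzyl, or a benzyl carrying a carboxylic acid, stays there.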